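Series notes: difluorophenyl variants on the ring nitrogen

A few compounds are considered here, and "the series" means these few. Any claim that something is new, unique, unknown or untested is made for them only; others in the source may bear on it.

In a functional assay on CHO cells with adenosine receptor A1 (Homo sapiens) as the target, read by cAMP accumulation and immunoassay, with a stated time of 6 min, tested at 0.01 uM (a higher number here means a weaker effect of the compound at the concentration tested, a lower number a stronger effect), compound 1 `Nc1scc(CN2CCN(c3ccccc3C(F)(F)F)CC2)c1C(=O)c1ccc(Cl)cc1` gives 0%. Compound 2 `Nc1scc(CN2CCN(c3c(F)cccc3F)CC2)c1C(=O)c1ccc(Cl)cc1` carries 2,6-difluorophenyl in place of 2-(trifluoromethyl)phenyl on an amine nitrogen in a ring, and in this assay compound 2 gives -12%. The measured step is a number 12 percentage points lower from compound 1 to compound 2 (beyond the scatter), which leaves compound 2 with the lowest of the two numbers in this assay; its nearest neighbour is compound 1, higher by a margin beyond the scatter.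

Compound 3 `Nc1scc(CN2CCN(c3cc(F)ccc3F)CC2)c1C(=O)c1ccc(Cl)cc1` has not yet been measured. It differs from compound 2 by 2,5-difluorophenyl in place of 2,6-difluorophenyl on an amine nitrogen in a ring. Among the measured compounds shown here, no measured step bears directly on this exchange: the only step in hand replaced the whole group on that ring nitrogen, whereas compound 3 keeps the same atoms joined differently. Both measured values sit close to zero activity at this concentration, and nothing in the pair points to a large swing from this exchange. The expected step is therefore a number 6 percentage points higher from compound 2 to compound 3 (within the scatter), not beyond the scatter. Compound 3 is estimated at -6% in this assay, with a range from -28% to 16%.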

Compound 3, a percentage reported as activity, at one concentration (the size of the read-out at that concentration, not a potency): 3.1%
Compound 3: the middle estimate sits 9.1 percentage points below what was measured; low and high end bracket the measured number.
By their numbers in this assay, from the lowest: compound 2; then compounds 1 and 3 (each within the scatter of the next).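

In this assay, rearranging the same atoms on this phenyl ring is enough to register, with a number 15.1 percentage points higher from compound 2 to compound 3 (beyond the scatter) for 2,5-difluorophenyl in place of 2,6-difluorophenyl, so at this place the read-out depends on how the two fluorines are arranged and not only on their presence. Exchanging the whole group gives a different picture, with a number 3.1 percentage points higher from compound 1 to compound 3 (within the scatter) for 2,5-difluorophenyl in place of 2-(trifluoromethyl)phenyl, so these two groups cannot be told apart here, and among the three compounds only compound 2, with its 2,6-difluorophenyl group, stands apart from the other two. Nothing at hand explains why the two difluorophenyl arrangements differ.

Open, on these data alone, is whether the separation belongs to 2,6-difluorophenyl alone or would also appear with other arrangements, such as 2,4-difluorophenyl or 3,5-difluorophenyl, or with a different group on the ring nitrogen, such as 2-methoxyphenyl or 2-chlorophenyl. All of these readings also come from a single concentration and lie close to zero, so they leave open whether the gap between the two difluorophenyl groups would persist at other concentrations or in a full potency measurement.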